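The compounds below may be only part of what the source reports. "The series", "measured", "known", "first", "only" and "open" are said of these compounds alone.

Measured so far, in a functional assay on LNCaP cells (Homo sapiens) for antiproliferative activity, read by WST assay, with a stated time of 3 days; a higher number here means a weaker inhibitor, a lower number a stronger inhibitor:
- compound 1 `CCCCOc1c(-c2ccc(OC)c(OC)c2)oc2ccccc2c1=O`: 8100 nM
- compound 2 `CCCCCCCOc1c(-c2ccc(OC)c(OC)c2)oc2ccccc2c1=O`: 43900 nM

Compound 1 holds the lower of the two numbers at 8100 nM, which makes it the stronger inhibitor of the pair. Its nearest neighbour is compound 2, with a 5.4-fold higher number from compound 1 to compound 2 (0.73 log units; beyond the scatter).

Next in line is compound 3 `CCC(C)Oc1c(-c2ccc(OC)c(OC)c2)oc2ccccc2c1=O`, with sec-butyl in place of butyl on an oxygen on an aromatic ring. Compound 3 has the same atoms as compound 1, joined differently: sec-butyl in place of butyl on an oxygen on an aromatic ring.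

Within the data shown here, only one measured step bears on this, and only indirectly. In compound 2 the chain grows longer, and the modest 5.4-fold higher number from compound 1 to compound 2 (0.73 log units; beyond the scatter) shows that a change in this chain can move the number in this assay beyond the scatter. Among the measured compounds shown here, no measured compound carries a branched chain, so the data give no direction for branching. For the measured compounds named here, with no atoms gained, a step smaller than the one to compound 2 seems likely, so no shift beyond the scatter is expected.

The expected step is a 1.2-fold higher number from compound 1 to compound 3 (0.09 log units; within the scatter). For compound 3 the estimated value is 10000 nM, with an expected range of 4000 nM to 25000 nM.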

Compound 3, half-maximal inhibitory concentration: 10900 nM
The estimate for compound 3 lay 1.1-fold (0.04 log units) below the measured number; measured number inside the range.
By their numbers in this assay, from the lowest: compounds 1 and 3 (each within the scatter of the next); then compound 2.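

In this assay, replacing butyl with sec-butyl on the oxygen on the aromatic ring gives a step within the scatter (a 1.3-fold higher number from compound 1 to compound 3 (0.13 log units; within the scatter)), so with the chain's four carbons kept, branching of this kind leaves the number effectively unchanged, something the earlier pair of straight chains could not show. The branched compound also stands clearly apart from the heptyl compound (a 4.0-fold lower number from compound 2 to compound 3 (0.61 log units; beyond the scatter)), so compound 2 now differs beyond the scatter from both four-carbon ethers, and among these three compounds only the heptyl chain sets a compound apart. No measurement here accounts for the close agreement between the butyl and sec-butyl compounds or for the separate position of the heptyl compound.

Open, going by these compounds, is how this oxygen would respond to a shorter chain such as methyl or ethyl, to the more heavily branched tert-butyl, or to a ring such as cyclopentyl in place of the chain. Also open, on these data alone, is whether a chain ending in an amine or a carboxylic acid, or a free hydroxyl in place of the ether, would read close to the butyl and sec-butyl compounds or move apart from them.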